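Trifluoromethyl for methoxy on a tetrazolyl quinoline core

The source may report more compounds than this note shows. Statements on the series, on what has been measured and on what is new or still open speak of the compounds shown alone.

In a functional assay on the whole organism (strain Sprague-Dawley) for inhibition, with Rattus norvegicus as the target (on this read-out lower numbers stand for an effect already at smaller amounts and higher numbers for an effect only at larger amounts of compound), compound 1 `COc1ccc2cc(-c3nn[nH]n3)cnc2c1` gives 5 mg/kg. Compound 2 `COc1cccc2cc(-c3nn[nH]n3)cnc12` is built from the same atoms joined differently, and the difference between the two cores is not broken down here. In this assay compound 2 gives 2.5 mg/kg, which lies within the usual scatter of the number of compound 1. Compound 3 `FC(F)(F)c1ccc2cc(-c3nn[nH]n3)cnc2c1` gives only a limit in this assay, < 10 mg/kg. The change trifluoromethyl in place of methoxy on an aromatic carbon therefore yields a step that the limit leaves unreadable from compound 1 to compound 3, its size hidden due to the limit of < 10 mg/kg in this assay, at which 1 of the 3 values shown sits.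

Compound 4 `FC(F)(F)c1cccc2cc(-c3nn[nH]n3)cnc12` carries the same kind of change relative to compound 2, (trifluoromethyl in place of methoxy on an aromatic carbon), though the place differs: here the group sits ortho to a fused ring and meta to a fused ring, whereas from compound 1 to compound 3 it sits meta to a fused ring and para to a fused ring. Beside the earlier unreadable step, the expected step is a 2.0-fold higher number from compound 2 to compound 4 (0.30 log units; within the scatter), resting on the dose compound 2 gives, 2.5 mg/kg, and on a step that the limit leaves unreadable from compound 1 to compound 3. Compound 4 is thus estimated at 5 mg/kg, between 1.5 mg/kg and 15 mg/kg.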

Compound 4, minimum effective dose: < 25 mg/kg
Compound 4 was reported as a limit (the forecaster's own chance of this, stated with the estimate: 30%); the middle value lies beyond the limit too.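

Going by these compounds alone, compound 4 is reported only as a limit, so no step from compound 2 to compound 4 can be read, due to that limit: the limit of < 25 mg/kg in this assay, at which 1 of the 4 values shown sits.

The compounds shown leave open whether trifluoromethyl in place of methoxy changes the minimum effective dose at all, at either place on the shared core.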